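A few compounds are considered here, and "the series" means these few. Any claim that something is new, unique, unknown or untested is made for them only; others in the source may bear on it.

Compound 1 `N/C(=N\NC(=S)N1CCCC1)c1ccc(F)cn1` was tested in a functional assay on HeLa cells (Homo sapiens) for cytotoxicity, read by MTT assay, with a stated time of 72 h, tested at 30 uM (on this read-out lower numbers stand for less inhibition of growth and higher numbers for more inhibition of growth at the one concentration tested), and gives 81.2%. Compound 2 `Cc1ccnc(/C(N)=N/NC(=S)N2CCN(c3ccccn3)CC2)c1` gives 77% in this assay; the two numbers lie within the usual scatter of each other, so neither stands apart. Compound 3 `N/C(=N\NC(=S)N1CCSCC1)c1ccc(F)cn1` has not yet been measured in this assay. It differs from compound 1 in one place: thiomorpholin-4-yl in place of pyrrolidin-1-yl on a thiocarbonyl carbon. Going by the values given here, no measured pair shows what this exchange does, so the expected step of a number 3.2 percentage points lower from compound 1 to compound 3 (within the scatter) is small, not beyond the scatter in either direction. Compound 3 is therefore estimated at 78%, with a range from 60% to 90%.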

Compound 3, percent growth inhibition at one concentration: 81.7%
The estimate for compound 3 lay 3.7 percentage points below the measured number; measured number inside the range.
By their numbers in this assay, from the lowest: compounds 2, 1 and 3 (each within the scatter of the next).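

In this assay, putting thiomorpholin-4-yl in place of pyrrolidin-1-yl on a thiocarbonyl carbon gives a number 0.5 percentage points higher from compound 1 to compound 3 (within the scatter). This first measured example of the exchange shows that this place tolerates the six-membered ring with its added sulfur: the growth inhibition stays the same within the scatter. As far as these compounds go, whether a smaller or open-chain group, such as azetidin-1-yl or diethylamino, would also leave the number unchanged remains open. No measured property is available to explain why these two rings give matching results.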